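Removing a methyl from the shared core: compound 4

A few compounds are considered here, and "the series" means these few. Any claim that something is new, unique, unknown or untested is made for them only; others in the source may bear on it.

Of the compounds shown here, three with the same core have been tested in a functional assay on Malme-3M cells (Homo sapiens) for inhibition, read by sulforhodamine B assay, with a stated time of 48 h; a higher number here means a weaker inhibitor of growth, a lower number a stronger inhibitor of growth. Compound 1 `O=C(Nc1cccc(-n2cc(-c3ccncc3)c(-c3ccc(Cl)c(O)c3)n2)c1)Nc1cccc(C(F)(F)F)c1` gives 1810 nM. Compound 2 `COc1cc(-c2nn(-c3cccc(NC(=O)Nc4cc(C(F)(F)F)cc(C(F)(F)F)c4)c3)cc2-c2ccncc2)ccc1Cl` gives 892 nM. Compound 3 `COc1cc(-c2nn(-c3cccc(NC(=O)Nc4cccc(C(F)(F)F)c4)c3)cc2-c2ccncc2)ccc1Cl` gives 1050 nM. Compound 2 has the lowest of the three numbers; its nearest neighbour is compound 3, within the scatter, while compound 1 lies beyond it.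

Compound 4 `O=C(Nc1cccc(-n2cc(-c3ccncc3)c(-c3ccc(Cl)c(O)c3)n2)c1)Nc1cc(C(F)(F)F)cc(C(F)(F)F)c1` has not yet been measured. It differs from compound 2 in one place: hydrogen in place of methyl on an oxygen on an aromatic ring. Among the compounds with values here, one measured step bears directly on this change, in the opposite direction: a 1.7-fold lower number from compound 1 to compound 3 (0.24 log units; within the scatter). Reversing that step suggests that taking the methyl away should, if anything, give a somewhat higher number, though the measured step itself stayed within the scatter. The other step, a 1.2-fold higher number from compound 2 to compound 3 (0.07 log units; within the scatter), concerns a trifluoromethyl group elsewhere and does not touch the change in question.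

Compound 4 is therefore expected to show a modestly higher number than compound 2, a step of a 1.7-fold higher number from compound 2 to compound 4 (0.23 log units; within the scatter), which is not expected to exceed the scatter. The estimate for compound 4 in this assay is 1500 nM, with a range from 700 nM to 3200 nM.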

Compound 4, concentration for 50% growth inhibition: 939 nM
For compound 4 the middle estimate is 1.6-fold (0.20 log units) above the measured one; low and high end bracket the measured number.
By their numbers in this assay, from the lowest: compounds 2, 4, 3 and 1 (each within the scatter of the next, the first and the last beyond it).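

In this assay, the change from methoxy to hydroxy can now be read on a second core, one carrying two trifluoromethyl groups, and there it gives a 1.1-fold higher number from compound 2 to compound 4 (0.02 log units; within the scatter). Taking the methyl off this oxygen therefore stays within the scatter on both cores, and the two readings agree with each other: the same change on two cores in this assay, a 1.7-fold lower number (0.24 log units; within the scatter) from compound 1 to compound 3 and a 1.1-fold lower number (0.02 log units; within the scatter) from compound 4 to compound 2, 1.6-fold (0.21 log units) apart, within the scatter of two such steps The second trifluoromethyl group, so far read only with the methoxy group present, can now also be read with the hydroxy group, where it gives a 1.9-fold lower number from compound 1 to compound 4 (0.29 log units; within the scatter), and this reading stays within the scatter and agrees with the earlier one: the same change on two cores in this assay, a 1.2-fold higher number (0.07 log units; within the scatter) from compound 2 to compound 3 and a 1.9-fold higher number (0.29 log units; within the scatter) from compound 4 to compound 1, 1.6-fold (0.21 log units) apart, within the scatter of two such steps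

The compounds shown carry only hydrogen or methyl on this oxygen, so it remains open whether a longer chain such as ethyl, or an amine in place of the oxygen, would shift the number beyond the scatter. From the compounds shown here alone, all of these numbers also come from this assay, so whether the same small steps appear in any other test remains unknown.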